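The source may hold more compounds than are shown below. What is called first, only, known or untested is meant among the compounds shown, and "the series" means these compounds.

In an ADME assay on Vero cells (Chlorocebus sabaeus) for cytotoxicity, read by MTT assay (on this read-out lower numbers stand for higher toxicity in this test and higher numbers for lower toxicity in this test), compound 1 `Cn1nc(C(F)(F)F)cc1C(=O)Nc1ccc(S(=O)(=O)N2CCCCCC2)cc1` gives > 300000 nM, which is a limit and not a number. Among the compounds with values here, compound 2 `Cn1nc(C(F)(F)F)cc1C(=O)Nc1ccc(S(=O)(=O)NC2CCCCC2)cc1` gives 15000 nM, the only actual number so far.

The next compound, compound 3 `Cn1nc(C(F)(F)F)cc1C(=O)Nc1ccc(S(=O)(=O)N2CCNCC2)cc1`, has not yet been measured. Within the data shown here, it is changed at the same place as the one measured step: piperazin-1-yl in place of cyclohexylamino on a sulfonyl sulfur. In words, piperazin-1-yl stands in place of cyclohexylamino on a sulfonyl sulfur.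

The measured step that bears on this change is an at least 20-fold lower number from compound 1 to compound 2 (1.30 log units; beyond the scatter), and it is large. Cyclohexylamino, the group that entered in that step, now leaves again, so part of the step is expected to be undone. Piperazin-1-yl is not azepan-1-yl, however, and a single step is thin support, so only a moderate rise is expected, towards lower toxicity in this test. The expected change is a 4.0-fold higher number from compound 2 to compound 3 (0.60 log units; beyond the scatter). For compound 3 the estimated value is 60000 nM, with an expected range from 15000 nM to 300000 nM.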

Compound 3, half-maximal cytotoxic concentration: 126000 nM
Compound 3: the middle estimate sits 2.1-fold (0.32 log units) below what was measured; low and high end bracket the measured number.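

In this assay, piperazin-1-yl in place of cyclohexylamino on the sulfonyl sulfur gives an 8.4-fold higher number from compound 2 to compound 3 (0.92 log units; beyond the scatter), so the low number seen with cyclohexylamino does not carry over to every six-membered non-aromatic ring at this place. Piperazin-1-yl in place of azepan-1-yl gives an at least 2.3-fold lower number from compound 1 to compound 3 (0.37 log units; beyond the scatter), which shows that this read-out also separates these two rings, even though both give far higher numbers than cyclohexylamino. The size of that second step is known only as a bound, because compound 1 stands at a limit and not at a number: the limit of > 300000 nM in this assay, at which 1 of the 3 values shown sits.

Cyclohexylamino and piperazin-1-yl differ in more than one respect, including ring size in heavy atoms, the hetero atoms in the ring and the count of hydrogen-bond acceptors, so the compounds shown cannot tell which of these differences goes with the rise. A piperidin-1-yl or morpholin-4-yl ring, or an open-chain amine such as diethylamino, on the same sulfonyl sulfur would help to pull these differences apart.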